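This account rests on a few compounds, and the source may have more. Where it says the series, first, only, none or still open, it means among the compounds named here.

Compound 1, `O=C(c1ccn(-c2ccc3c(c2)B(O)OC3)c1)c1ccccc1Cl`, compound 2, `CCc1ccc(C(=O)c2ccn(-c3ccc4c(c3)B(O)OC4)c2)cc1`, and compound 3, `CC(=O)OCc1ccc(C(=O)c2ccn(-c3ccc4c(c3)B(O)OC4)c2)cc1`, were tested in an ADME assay on L929 cells (Mus musculus) for cytotoxicity, read by resazurin assay, with a stated time of 72 h; on this read-out higher numbers stand for weaker inhibition and lower numbers for stronger inhibition. In this assay compound 1 reaches only the limit of the assay, > 10 ug/mL. In the same assay compound 2 likewise gives a limit, > 10 ug/mL. For the measured compounds named here, compound 3 is the one compound with a number, giving 10 ug/mL in this assay, so it stands at the edge of what the assay resolves, at the limit of > 10 ug/mL in this assay, at which 2 of the 3 values shown sit.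

The next step leads to compound 4, `NCc1ccc(C(=O)c2ccn(-c3ccc4c(c3)B(O)OC4)c2)cc1`, through (amino in place of acetoxy on a saturated chain carbon bound to an aromatic carbon). Going by the values given here, two measured steps touch the same part of the molecule or the same read-out. The change at the chain carbon bound to an aromatic carbon, a number no higher from compound 2 to compound 3 (the limit leaves the size open), cannot be sized, and the step that the two limits leave unreadable from compound 1 to compound 2 is equally unreadable. With both steps hidden by the limit, no direction can be drawn for the amino group, and no change beyond the scatter of this assay is expected from compound 3 to compound 4, so the step is estimated as no change at the digits printed from compound 3 to compound 4 (within the scatter). Compound 4 is therefore expected to give about 10 ug/mL in this assay, within 5 ug/mL to 20 ug/mL, with a fair chance that only the limit is reported.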

Compound 4, half-maximal inhibitory concentration: > 10 ug/mL
Compound 4 ended at the assay's limit; the forecaster's own chance of this, stated with the estimate: 60%; the middle value sits exactly at the limit.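

At the saturated chain carbon bound to an aromatic carbon, amino in place of acetoxy gives, in this assay, a number no lower from compound 3 to compound 4 (the limit leaves the size open). The result for compound 4 is a limit of the assay, as are those for compound 1 and compound 2, and the steps among these three compounds cannot be read. With methyl, acetoxy and amino now shown at this place, acetoxy in compound 3 remains the only group with a number, and the set sits largely at one edge of the read-out: the limit of > 10 ug/mL in this assay, at which 3 of the 4 values shown sit.

The compounds shown leave open how far the values of compound 1, compound 2 and compound 4 lie past the limit, and therefore whether amino differs from methyl at this place at all. They also leave open whether a carboxylic acid, a dimethylamino group or a longer chain ending in an amine at the same chain carbon would give a number in this assay.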